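Swapping a Benzothiophene for a Fluorinated Amide

The source may hold more compounds than are shown below. What is called first, only, known or untested is meant among the compounds shown, and "the series" means these compounds.

Of the compounds shown here, three have been measured in an assay on isolated protein for inhibition of tyrosine-protein kinase Fes/Fps (Homo sapiens), read by HTRF, tested at 10 uM; a higher number here means more inhibition at the concentration tested (going by the name of the read-out), a lower number less inhibition. Compound 1 `COC[C@@H]1CCCN1C(=O)[C@@H]1CCCN1c1cc(Nc2cccc(OC)c2)nc(N)n1` gives 8%, compound 2 `Cc1cccc(Oc2ccnc(N3CCN(C(=O)c4c(C)noc4C)CC3)n2)c1` gives 7%, and compound 3 `Clc1ccc2sc(CN3CCN(c4ncnc5c4CN(Cc4ccccc4)CC5)CC3)cc2c1` gives 6%. Compound 3 carries the lowest of the three numbers, yet its gaps to compound 2 and to compound 1 both lie within the usual scatter, so none of the three can be told apart. Compound 4 `O=C(CN1CCN(c2ncnc3c2CN(Cc2ccccc2)CC3)CC1)Nc1cc(F)ccc1F` has not yet been measured. Among the measured compounds shown here, it differs from compound 3 in one place: (2,5-difluorophenyl)carbamoyl in place of 5-chloro-1-benzothiophen-2-yl on a saturated chain carbon bound to an amine nitrogen in a ring No measured pair shares this change, so there is nothing to size it from. With all three numbers low and indistinguishable, the step of a number 1 percentage points higher from compound 3 to compound 4 (within the scatter) is expected to stay within the scatter. Compound 4 is estimated at 7%, ranging from -5% to 22%.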

Compound 4, a percentage reported as inhibition, at one concentration (the size of the read-out at that concentration, not a potency): 11%
Compound 4: middle estimate off by 4 percentage points, on the low side; low and high end bracket the measured number.
By their numbers in this assay, from the lowest: compounds 3, 2, 1 and 4 (each within the scatter of the next).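

In this assay, among the compounds shown here, the step of a number 5 percentage points higher from compound 3 to compound 4 (within the scatter) gives the first reading at this position: on a saturated chain carbon bound to an amine nitrogen in a ring, 5-chloro-1-benzothiophen-2-yl and (2,5-difluorophenyl)carbamoyl cannot be told apart. These groups differ in their aromatic rings and in the amide hydrogen, which only the second carries, yet the difference stays within the scatter. No measurement on hand offers an explanation for this result.

From the compounds shown here alone, it remains open whether a simple amine or a carboxylic acid at this position would give a number clearly beyond the scatter.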